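A tert-butyl for the isopropoxy chain on compound 3

A few compounds are considered here, and "the series" means these few. Any claim that something is new, unique, unknown or untested is made for them only; others in the source may bear on it.

Compound 3 `CC(C)OCCOc1cccc2ccc(N)nc12` reaches only the limit of an assay on cells with melanin-concentrating hormone receptor 1 (Homo sapiens) as the target, read by radioligand binding (a higher number here means a weaker inhibitor, a lower number a stronger inhibitor), where it gives > 2000 nM, a limit and not a number (the limit of > 2000 nM in this assay, at which 2 of the 3 values shown sit). Compound 1 `CCOCCOc1cccc2ccc(N)nc12` also sits at that limit, with > 2000 nM. Compound 2 `Nc1ccc2cccc(OCCC(F)(F)F)c2n1` gives 722 nM in this assay. Compound 4 `CC(C)(C)CCOc1cccc2ccc(N)nc12` differs from compound 3 by tert-butyl in place of isopropoxy on a saturated chain carbon, two bonds along the chain from an oxygen on an aromatic ring. For the measured compounds named here, the steps that bear on this are an at least 2.7-fold higher number from compound 2 to compound 3 (0.44 log units; beyond the scatter) and an at least 2.7-fold lower number from compound 1 to compound 2 (0.44 log units; beyond the scatter): in both, the compound without a hydrogen-bond acceptor in the chain gave the lower number. A similar step is therefore expected here, downward and modest, an at least 2.2-fold lower number from compound 3 to compound 4 (0.34 log units; beyond the scatter). Compound 4 is estimated at 900 nM in this assay, between 250 nM and 3000 nM.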

Compound 4, half-maximal inhibitory concentration: 201 nM
For compound 4 the middle estimate is 4.5-fold (0.65 log units) above the measured one, and the stated range ends above it.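

In this assay, replacing the oxygen-bearing end of the chain with tert-butyl gives an at least 9.9-fold lower number from compound 3 to compound 4 (0.99 log units; beyond the scatter) and an at least 9.9-fold lower number from compound 1 to compound 4 (0.99 log units; beyond the scatter). Both sizes are only floors, since compound 1 and compound 3 each stay at a limit: the limit of > 2000 nM in this assay, at which 2 of the 4 values shown sit.

For the compounds shown here, the one step with a full size, a 3.6-fold lower number from compound 2 to compound 4 (0.56 log units; beyond the scatter), shows that this position still separates two groups that both lack the oxygen of ethoxy and isopropoxy, so losing that oxygen does not alone set the value.

From the compounds shown here alone, whether cyclohexyl or a longer alkyl chain would lower the number further stays open, as does how an amine would read at this place.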